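The source may report more compounds than this note shows. Statements on the series, on what has been measured and on what is new or still open speak of the compounds shown alone.

Compound 1 `CCN(CC)CCCOc1cc2oc(-c3ccccc3)cc(=O)c2c(O)c1OC`: 23400 nM
Compound 2 `COc1c(OCCCN2CCN(C)CC2)cc2oc(-c3ccccc3)cc(=O)c2c1O`: 42500 nM

Both values come from a functional assay on HCT-116 cells (Homo sapiens) for antiproliferative activity, read by MTT assay, with a stated time of 48 h; on this read-out lower numbers stand for stronger inhibition and higher numbers for weaker inhibition. Compound 2 stands within the scatter of compound 1, so the two are not separated on these numbers. Compound 3 `COc1c(OCCCCN2CCN(C)CC2)cc2oc(-c3ccccc3)cc(=O)c2c1O` differs from compound 2 as follows: (4-methylpiperazin-1-yl)methyl in place of 4-methylpiperazin-1-yl on a saturated chain carbon, three bonds along the chain from an oxygen on an aromatic ring. In words, this is 2-(4-methylpiperazin-1-yl)ethyl to 3-(4-methylpiperazin-1-yl)propyl. Within the data shown here, only one measured step bears on it: a 1.8-fold higher number from compound 1 to compound 2 (0.26 log units; within the scatter). That step falls on the same saturated chain carbon but exchanges the amine group, so it is indirect evidence. Among the measured compounds shown here, no measured pair varies the chain itself. With so little to go on, no step beyond the scatter is expected in this assay, and the range is kept wide. The expected step is a 1.2-fold lower number from compound 2 to compound 3 (0.08 log units; within the scatter). The estimate for compound 3 is 35000 nM, with an expected range of 14000 nM to 85000 nM.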

Compound 3, half-maximal inhibitory concentration: 12500 nM
The estimate for compound 3 lay 2.8-fold (0.45 log units) above the measured number; measured number outside the range, below it.
By their numbers in this assay, from the lowest: compounds 3, 1 and 2 (each within the scatter of the next, the first and the last beyond it).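

In this assay, among these compounds, the change from 2-(4-methylpiperazin-1-yl)ethyl to 3-(4-methylpiperazin-1-yl)propyl gives a 3.4-fold lower number from compound 2 to compound 3 (0.53 log units; beyond the scatter) and is the only step so far to pass beyond the scatter. Among the compounds shown here, the position on the saturated chain therefore responds to chain extension by a single carbon, which the amine exchange between the earlier compounds did not show. The result does not set the longer chain apart from the diethylamino side chain, since a 1.9-fold lower number from compound 1 to compound 3 (0.27 log units; within the scatter) leaves those two compounds unseparated.

Open, from the compounds shown here alone, is whether a still longer chain bearing 4-methylpiperazin-1-yl goes further, and whether a diethylamino group responds in the same way to one added carbon. No evidence at hand accounts for the step.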